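The compounds below may be only part of what the source reports. "The series", "measured", "known", "first", "only" and "open" are said of these compounds alone.

The two measured compounds, compound 1 `CCCc1nc(-c2ccccc2)c(CNCCN2CCN(c3cccc(C(F)(F)F)c3)CC2)o1` and compound 2 `CCCc1nc(-c2ccccc2)c(CNCCCN2CCN(c3ccc(F)cc3)CC2)o1`, share a core and differ in more than one place. In an assay on HEK293 cells for inhibition of Voltage-dependent T-type calcium channel subunit alpha-1G (Homo sapiens), read by patch clamp (on this read-out higher numbers stand for weaker inhibition and lower numbers for stronger inhibition), compound 1 gives 1940 nM. In this assay compound 2 gives 3210 nM, the highest of the two numbers; the two values lie within the scatter of each other, so no order between them can be read. The unmeasured compound 3 `CCCc1nc(-c2ccccc2)c(CNCCCN2CCN(c3cccc(C(F)(F)F)c3)CC2)o1` keeps the core of compound 2 and changes one place: 3-(trifluoromethyl)phenyl in place of 4-fluorophenyl on an amine nitrogen in a ring. For the measured compounds named here, the entering group is already present in compound 1, but compound 1 differs from compound 3 elsewhere, so no single step isolates this change. The values of compound 1 and compound 2 are all the data offer on it, and they lie within the scatter of each other. The expected step is therefore a 1.5-fold lower number from compound 2 to compound 3 (0.16 log units; within the scatter), not beyond the scatter. Compound 3 is estimated at 2200 nM, with a range from 800 nM to 6000 nM.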

Compound 3, half-maximal inhibitory concentration: 650 nM
For compound 3 the middle estimate is 3.4-fold (0.53 log units) above the measured one; measured number below the stated range.
By their numbers in this assay, from the lowest: compound 3; then compounds 1 and 2 (each within the scatter of the next).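

On the amine nitrogen in the six-membered ring, 3-(trifluoromethyl)phenyl in place of 4-fluorophenyl gives, in this assay, a 4.9-fold lower number from compound 2 to compound 3 (0.69 log units; beyond the scatter), so the group on this nitrogen changes the read-out when all else in the molecule stays fixed. Compound 1 and compound 2 could not show this, since they differ in more than one place and their values lie within the scatter of each other. Nothing given here bears on why the step has this size.

The single step changes the group's substituent and its place on the phenyl ring together, and the compounds shown do not separate the two; a plain phenyl or a chlorophenyl group on the same nitrogen would add to the picture. From the compounds shown here alone, whether the step keeps its size on the core of compound 1 also stays open.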